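One aryl swap, with one measured step to go on

The source may hold more compounds than are shown below. What is called first, only, known or untested is meant among the compounds shown, and "the series" means these compounds.

- Compound 1 `COc1cccc(/C=C/C(=O)N2Cc3ccccc3[C@@H](OCc3ccccc3)[C@@H]2CO)c1OC` gives 32800 nM
- Compound 2 `COc1cc(/C=C/C(=O)N2Cc3ccccc3[C@@H](OCc3ccccc3)[C@@H]2CO)ccc1O` gives 67600 nM

Going by the values given here, in a functional assay on HeLa cells (Homo sapiens) for antiproliferative activity, read by MTT assay, with a stated time of 48 h (on this read-out lower numbers stand for stronger inhibition and higher numbers for weaker inhibition), compound 2 gives 67600 nM, the higher of the two numbers so far. Its nearest neighbour, compound 1, gives 32800 nM. Compound 3 `O=C(/C=C/c1ccc([N+](=O)[O-])cc1)N1Cc2ccccc2[C@@H](OCc2ccccc2)[C@@H]1CO` keeps the shared core and changes one group: 4-nitrophenyl in place of 4-hydroxy-3-methoxyphenyl on a double-bonded chain carbon bound to a double-bonded chain carbon. Here 4-nitrophenyl comes in place of 4-hydroxy-3-methoxyphenyl on a double-bonded chain carbon bound to a double-bonded chain carbon.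

Among the compounds with values here, only one measured step bears on this, and it lies at the same place: a 2.1-fold higher number from compound 1 to compound 2 (0.31 log units; beyond the scatter). Within the data shown here, that step is modest and only just beyond the scatter, and no measured compound yet carries 4-nitrophenyl. Like compound 3, compound 1 has no hydroxy group on that phenyl ring, and it sits on the lower side at 32800 nM. A similarly modest move towards a lower number in this assay is therefore expected, although this direction rests on a single pair. The estimated change is a 1.5-fold lower number from compound 2 to compound 3 (0.18 log units; within the scatter). For compound 3 the estimate is 45000 nM, with an expected range of 15000 nM to 120000 nM.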

Compound 3, half-maximal inhibitory concentration: 26800 nM
Beside the measured number, compound 3's estimate is 1.7-fold (0.23 log units) above it; low and high end bracket the measured number.
By their numbers in this assay, from the lowest: compounds 3 and 1 (each within the scatter of the next); then compound 2.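

In this assay, the change from 4-hydroxy-3-methoxyphenyl to 4-nitrophenyl gives a clear, if modest, shift (a 2.5-fold lower number from compound 2 to compound 3 (0.40 log units; beyond the scatter)), the second step at this place on the chain to lie beyond the scatter. The change from 2,3-dimethoxyphenyl to 4-nitrophenyl gives no such shift (a 1.2-fold lower number from compound 1 to compound 3 (0.09 log units; within the scatter)), so these two differently substituted phenyl groups cannot be told apart here, and compound 2, the only one of the three with a hydroxy group on that ring, stands alone as the weakest. The data offer no measurement that would explain this difference.

Going by these compounds alone, with only three compounds, the link between the hydroxy group and the higher number remains a reading of a single compound, and compound 2 also carries a methoxy group that may share in the result. On these data alone, it remains open whether a plain phenyl, a 4-aminophenyl or a 4-carboxyphenyl group on this chain would stay level with compound 3 or move towards compound 2, and whether any group at this place could bring a larger step than those seen so far.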